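Demethylating the phenol in a pyrazole series: SNB-75 cell toxicity

The source may report more compounds than this note shows. Statements on the series, on what has been measured and on what is new or still open speak of the compounds shown alone.

Compounds measured so far:
Compound 1, `COc1cc(C)cc(-c2nn(CC#N)cc2-c2ccc(-c3cccc(C(C)=O)c3)nc2)c1`: > 100000 nM
Compound 2, `Cc1cc(O)cc(-c2nn(CC#N)cc2-c2ccnc(-c3ccc(Oc4ccccc4)cc3)c2)c1`: 42000 nM
Compound 3, `COc1cc(C)cc(-c2nn(CC#N)cc2-c2ccnc(-c3ccc(N(C)C)cc3)c2)c1`: > 100000 nM

These three compounds share a core carrying a nitrile-bearing side chain and differ in the substituents on their two outer aromatic rings. They were tested in a functional assay on SNB-75 cells (Homo sapiens) for inhibition, read by sulforhodamine B assay, with a stated time of 48 h; on this read-out lower numbers stand for higher toxicity in this test and higher numbers for lower toxicity in this test. For compound 1 the result is > 100000 nM, which is a limit of the assay rather than a number. Compound 2 gives 42000 nM. For compound 3 the result is again > 100000 nM, a limit of the assay and not a number, so compound 3 cannot be placed more precisely than at that limit; as the limit of > 100000 nM in this assay, at which 2 of the 3 values shown sit, shows, it shares this position with one other compound. Compound 2 is the only one of the three with a numerical value, and it carries a hydroxy rather than a methoxy group.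

Compound 4, `Cc1cc(O)cc(-c2nn(CC#N)cc2-c2ccnc(-c3ccc(N(C)C)cc3)c2)c1`, has not yet been measured. It differs from compound 3 by hydrogen in place of methyl on an oxygen on an aromatic ring. With no one-step comparison available, a step from compound 3 to compound 4 of the size an at least 1.4-fold lower number from compound 3 to compound 4 (0.15 log units; that floor lies within the scatter) is expected, toward the number seen for compound 2, though it could remain within the scatter. Compound 4 is therefore estimated at 70000 nM, within 30000 nM to 150000 nM.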

Compound 4, concentration lethal to 50% of the cells: > 100000 nM
Compound 4: no number, only a limit; the forecaster's own chance of this, stated with the estimate: 45%; middle value at least 1.4-fold (0.15 log units) from the limit.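

In this assay compound 4 sits at a limit of the assay and not at a number, as its methoxy partner did, so the step from methoxy to hydroxy on the aromatic ring cannot be read and shows neither a gain nor a loss of toxicity. With the hydroxy group present in both compounds, the change that can be read is dimethylamino in place of phenoxy on an aromatic carbon, which gives an at least 2.3-fold higher number from compound 2 to compound 4 (0.37 log units; beyond the scatter). A hydroxy group alone is therefore not enough to bring a numerical value in this series, and the only number shown belongs to the compound that carries the phenoxy group, while compound 4 joins the others at the ceiling: the limit of > 100000 nM in this assay, at which 3 of the 4 values shown sit.

What the change from methoxy to hydroxy does when phenoxy is present stays open, since the compounds shown include no methoxy partner of compound 2. Also open, from the compounds shown here alone, is whether a longer chain on that oxygen, such as ethoxy, or a carboxylic acid in place of the dimethylamino group would give a readable number.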